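Cytotoxicity notes on a tetrahydropyran series, compound 2 to compound 4

The compounds below may be only part of what the source reports. "The series", "measured", "known", "first", "only" and "open" are said of these compounds alone.

Measured so far in a functional assay on HL-60 cells (Homo sapiens) for cytotoxicity, read by WST assay, with a stated time of 48 h; a higher number here means a weaker inhibitor, a lower number a stronger inhibitor:
- compound 1, `COc1ccc(/C=C/C[C@@H]2C[C@@H]([C@@H](O)c3ccc(OC)c(OC)c3)CO[C@H]2c2ccc(OC)c(OC)c2)cc1OC`: 26000 nM
- compound 2, `COc1cccc(/C=C/C[C@H]2C[C@@H]([C@@H](O)c3ccccc3)CO[C@@H]2c2ccccc2)c1`: 9620 nM
- compound 3, `COc1ccc(/C=C/C[C@@H]2C[C@H]([C@H](O)c3ccc(OC)c(OC)c3)CO[C@H]2c2ccc(OC)c(OC)c2)cc1OC`: "not determined" (no result reported)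

Compound 2 holds the lowest of the two numbers obtained so far; compound 1 sits higher, and the gap between the two lies beyond the usual scatter of this assay. For compound 3 there is no number, so it adds nothing to the comparison; the only thing known of it is the fact that compounds 1 and 3 differ only in the configuration as drawn.

Compound 4, `Oc1ccccc1/C=C/C[C@H]1C[C@@H]([C@@H](O)c2ccccc2)CO[C@@H]1c1ccccc1`, is still unmeasured. It differs from compound 2 in one place: 2-hydroxyphenyl in place of 3-methoxyphenyl on a double-bonded chain carbon bound to a double-bonded chain carbon. The rest of the molecule, including the core and the two unsubstituted phenyl groups, is unchanged.

Among the compounds with values here, no step between measured compounds touches this position, so there is nothing that points to a direction. The expectation for compound 4 is therefore a step from compound 2 of about a 1.1-fold lower number from compound 2 to compound 4 (0.03 log units; within the scatter), that is, none beyond the scatter. On that basis compound 4 is estimated at 9000 nM, with a range from 3000 nM to 27000 nM.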

Compound 4, half-maximal inhibitory concentration: 10800 nM
Compound 4: middle estimate off by 1.2-fold (0.08 log units), on the low side; the measured number falls inside the stated range.
By their numbers in this assay, from the lowest: compounds 2 and 4 (each within the scatter of the next); then compound 1.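

Within the data shown here, this is the first step at this position: in this assay, 2-hydroxyphenyl in place of 3-methoxyphenyl on a double-bonded chain carbon bound to a double-bonded chain carbon gives a 1.1-fold higher number from compound 2 to compound 4 (0.05 log units; within the scatter), so this exchange leaves the read-out within the scatter. The group goes from 0 to 1 hydrogen-bond donors and from 8 to 7 heavy atoms, and neither difference comes with a step beyond the scatter in this pair. Nothing on hand bears on why the two compounds read alike.

The pair changes the oxygen substituent and its place on the phenyl ring together, so the two changes cannot be told apart here. Going by these compounds, whether an amine or a carboxylic acid on that phenyl ring, or a longer chain in place of the ethenyl link, would give a step beyond the scatter remains open.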